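This account rests on a few compounds, and the source may have more. Where it says the series, first, only, none or still open, it means among the compounds named here.

Of the compounds shown here, three have been measured in a functional assay on A549 cells (Homo sapiens), read by MTT assay, with a stated time of 72 h (on this read-out lower numbers stand for stronger inhibition and higher numbers for weaker inhibition), and a fourth awaits its result. Compound 1 `COc1nc(N)nc2c1c(-c1ccsc1)cn2[C@@H]1O[C@H](CO)[C@@H](O)[C@H]1O` and compound 2 `C#Cc1cn([C@@H]2O[C@H](CO)[C@@H](O)[C@H]2O)c2nc(N)nc(OC)c12` share one core, while compound 3 `C#Cc1cn([C@@H]2O[C@H](CO)[C@@H](O)[C@H]2O)c2ncnc(SC)c12` has another; how the two cores differ is not broken down here. In this assay compound 1 gives > 100000 nM, which is a limit of the assay rather than a number. In this assay compound 2 also gives > 100000 nM, again a limit. In this assay, among the measured compounds shown here, compound 3 gives 140 nM, the only plain number among the three.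

Compound 2 and compound 1 differ in one place: thiophen-3-yl in place of ethynyl on an aromatic carbon. The step that the two limits leave unreadable from compound 2 to compound 1 cannot be read, since both values sit at the limit of > 100000 nM in this assay, at which 2 of the 3 values shown sit. Compound 4 `CSc1ncnc2c1c(-c1ccsc1)cn2[C@@H]1O[C@H](CO)[C@@H](O)[C@H]1O` is the compound still to be measured; it arises from compound 3 by the same kind of change, (thiophen-3-yl in place of ethynyl on an aromatic carbon), and the two place descriptions agree word for word, so it is the same change made on the other core. Among the four compounds this change occurs twice, and the one measured instance tells nothing about its size. The expectation for compound 4 therefore rests on compound 3 alone, whose value 140 nM is the starting point, with wide room in either direction. The step from compound 3 to compound 4 is expected to be a 7.1-fold higher number from compound 3 to compound 4 (0.85 log units; beyond the scatter). For compound 4 the estimate in this assay is 1000 nM, with a range from 100 nM to 20000 nM.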

Compound 4, half-maximal inhibitory concentration: > 20000 nM
Compound 4: no number, only a limit (the forecaster's own chance of this, stated with the estimate: 15%); middle value at least 20-fold (1.30 log units) from the limit.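

In this assay, putting thiophen-3-yl in place of ethynyl on the core of compound 3 gives an at least 140-fold higher number from compound 3 to compound 4 (2.15 log units; beyond the scatter), so on this core the change goes with a large loss of inhibition. From the compounds shown here alone, compound 4 gives > 20000 nM, which is a limit of the assay and not a number, so the true size of the step stays unknown: the limit of > 20000 nM in this assay, at which 1 of the 4 values shown sits. The result therefore shows the change on one core only and does not show whether it would act the same way on the other core, since the step from compound 2 to compound 1 cannot be read when both values are limits: the limit of > 100000 nM in this assay, at which 2 of the 4 values shown sit.

The compounds shown leave open whether the loss is tied to thiophen-3-yl itself or would follow from other replacements of ethynyl at the same place, such as a methyl group, an amine, a phenyl ring or a longer chain like propynyl. They also leave open which feature of compound 3 goes with its activity, as the two cores differ and no listed pair isolates that difference, and a core bearing ethynyl with a methylsulfanyl group and an amine together would be one way to narrow this.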